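This account rests on a few compounds, and the source may have more. Where it says the series, first, only, none or still open, it means among the compounds named here.

Among the compounds with values here, in an ADME assay on HCT-116 cells (Homo sapiens) for cytotoxicity, read by CellTiter-Glo, with a stated time of 72 h (a higher number here means a weaker inhibitor, a lower number a stronger inhibitor), neither of the two compounds measured so far gives a number. Compound 1 `CC1CCN(C2CCN(S(=O)(=O)c3cnc(Cl)s3)CC2)CC1` reads > 10000 nM, which is a limit of the assay. Compound 2 `COc1cccc(S(=O)(=O)N2CCC(N3CCC(C)CC3)CC2)c1` reads > 5000 nM, and this too is a limit, so compound 2 has no exact position. Within the data shown here, the only measured step is a step that the two limits leave unreadable from compound 1 to compound 2. It also replaces the group on the sulfonyl sulfur, but it gives no size to carry forward. Compound 3 `CC1CCN(C2CCN(S(=O)(=O)c3ccc(Br)c(Cl)c3)CC2)CC1` has 4-bromo-3-chlorophenyl in place of 3-methoxyphenyl on a sulfonyl sulfur. With so little to go on, only a modest shift towards stronger inhibition in this assay is expected, and a further limit remains quite possible. The expected change is a number no higher from compound 2 to compound 3 (the limit leaves the size open). For compound 3 the estimated value is 5000 nM, with an expected range of 1500 nM to 15000 nM.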

Compound 3, half-maximal inhibitory concentration: > 5000 nM
Compound 3 was reported as a limit; the forecaster's own chance of this, stated with the estimate: 55%; the middle value sits exactly at the limit.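

In this assay compound 3 reads > 5000 nM, which is a limit of the assay. Within the data shown here, as compound 1, compound 2 and compound 3 all stand as limits, no step among them can be read. The compounds shown leave open whether any of these groups on the sulfonyl sulfur differs from the others in this assay.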